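Swapping the Ring Nitrogen Substituent from Ethyl to Pivaloyl

This account rests on a few compounds, and the source may have more. Where it says the series, first, only, none or still open, it means among the compounds named here.

Measured compounds:
- compound 1, `CNc1ncc2c(-c3ccc(N4CCNCC4)nc3)nn(CC3CCCC3)c2n1`: 120 nM
- compound 2, `CNc1ncc2c(-c3ccc(N4CCN(C)CC4)nc3)nn(CC3CCCC3)c2n1`: 70 nM
- compound 3, `CCN1CCN(c2ccc(-c3nn(CC4CCCC4)c4nc(NC)ncc34)cn2)CC1`: 260 nM

In an assay for inhibition of tyrosine-protein kinase receptor UFO (Homo sapiens), read by 33P incorporation, in the presence of a further agent that is not named here (on this read-out lower numbers stand for stronger inhibition and higher numbers for weaker inhibition), compound 3 gives the highest of the three numbers. Its nearest neighbour is compound 1, with a 2.2-fold higher number from compound 1 to compound 3 (0.34 log units; beyond the scatter), and furthest is compound 2, with a 3.7-fold higher number from compound 2 to compound 3 (0.57 log units; beyond the scatter). Compound 1 and compound 2 differ only by a 1.7-fold lower number from compound 1 to compound 2 (0.23 log units; within the scatter), a step within the scatter.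

Compound 4, `CNc1ncc2c(-c3ccc(N4CCN(C(=O)C(C)(C)C)CC4)nc3)nn(CC3CCCC3)c2n1`, has not been measured. It differs from compound 3 by (tert-butyl)carbonyl in place of ethyl on an amine nitrogen in a ring.

For the measured compounds named here, the steps that bear on this are the two that change the group on the same ring nitrogen: from hydrogen to ethyl, a 2.2-fold higher number from compound 1 to compound 3 (0.34 log units; beyond the scatter), and from methyl to ethyl, a 3.7-fold higher number from compound 2 to compound 3 (0.57 log units; beyond the scatter). Both times the bulkier group gave a higher number, though both steps were modest. Going by the values given here, the group that now enters is larger again, and no measured compound carries an acyl group there, so the expectation rests on a short trend from three compounds only.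

For compound 4 a further modest rise is therefore expected, a 1.7-fold higher number from compound 3 to compound 4 (0.24 log units; within the scatter), giving an estimate of 450 nM with a likely range from 120 nM to 1800 nM.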

Compound 4, half-maximal inhibitory concentration: 7200 nM
Compound 4: the middle estimate sits 16-fold (1.20 log units) below what was measured, and the stated range ends below it.
By their numbers in this assay, from the lowest: compounds 2 and 1 (each within the scatter of the next); then compound 3; then compound 4.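

In this assay this ring nitrogen shows something the hydrogen, methyl and ethyl compounds gave no sign of: a 28-fold higher number from compound 3 to compound 4 (1.44 log units; beyond the scatter), a large step where those three compounds differed from one another by modest steps at most. The comparisons with the smaller groups point the same way, with a 100-fold higher number from compound 2 to compound 4 (2.01 log units; beyond the scatter) and a 60-fold higher number from compound 1 to compound 4 (1.78 log units; beyond the scatter), both also large, so (tert-butyl)carbonyl on this amine nitrogen stands well apart from all three earlier groups and does not simply extend their short trend. Nothing available here explains this jump.

The change adds a carbonyl and a tert-butyl group together, so the compounds shown cannot separate the two: an acetyl group would keep the carbonyl without the tert-butyl, while a neopentyl chain would keep the tert-butyl without the carbonyl. Going by these compounds, it also remains open how other groups on this nitrogen would behave, such as a 2-hydroxyethyl chain or a chain ending in an amine, and whether any of them would give a number close to those of compound 1 and compound 2.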